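The compounds below may be only part of what the source reports. "The series", "measured", "known", "first", "only" and "open" are said of these compounds alone.

Compound 1 `C#Cc1cn([C@@H]2O[C@H](CO)[C@@H](O)[C@H]2O)c2ncnc(NC)c12`: 1380 nM
Compound 2 `Nc1nc(N)c2c(-c3cccs3)cn([C@@H]3O[C@H](CO)[C@@H](O)[C@H]3O)c2n1`: > 20000 nM (a limit)
Compound 3 `COc1nc(N)nc2c1c(-c1cccs1)cn2[C@@H]1O[C@H](CO)[C@@H](O)[C@H]1O`: > 20000 nM (a limit)

In a functional assay on K562 cells (Homo sapiens), read by MTT assay, with a stated time of 72 h (a lower number here means a stronger inhibitor, a higher number a weaker inhibitor), compound 3 gives > 20000 nM, which is only a limit and not a number. Compound 4 `C#Cc1cn([C@@H]2O[C@H](CO)[C@@H](O)[C@H]2O)c2nc(N)nc(OC)c12` has not been measured, and it differs from compound 3 as follows: ethynyl in place of thiophen-2-yl on an aromatic carbon. Within the data shown here, the one measured step, a step that the two limits leave unreadable from compound 2 to compound 3, concerns methoxy in place of amino and gives no size. The nearest guide is compound 1, which also carries ethynyl on a core that differs elsewhere and gives 1380 nM. On that basis, the expected step towards stronger inhibition in this assay is an at least 3.3-fold lower number from compound 3 to compound 4 (0.52 log units; beyond the scatter), with a real chance that no number is obtained. For compound 4 the estimate is 6000 nM, with an expected range from 1000 nM to 20000 nM.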

Compound 4, half-maximal inhibitory concentration: > 20000 nM
Compound 4 ended at the assay's limit (the forecaster's own chance of this, stated with the estimate: 35%); middle value at least 3.3-fold (0.52 log units) away from the limit.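

In this assay no step can be read from compound 3 to compound 4, because both values are limits: the limit of > 20000 nM in this assay, at which 3 of the 4 values shown sit. The compounds shown leave open whether ethynyl in place of thiophen-2-yl changes inhibition at all on this core.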